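The source may report more compounds than this note shows. Statements on the series, on what has been measured and on what is new or still open speak of the compounds shown alone.

In a physicochemical assay for solubility (a higher number here means a more soluble compound, a lower number a less soluble compound), three measured compounds frame this step, and only one of them gives a number. Among the measured compounds shown here, compound 2 (`O=C(Nc1ccc([N+](=O)[O-])cc1)c1cc(Cl)ccc1O`) gives 6.4 ug/mL in this read-out, the sole value in the set that is not a limit. Compound 1 (`O=C(Nc1ccc([N+](=O)[O-])cc1Cl)c1cc(-c2ccc(F)cc2F)ccc1O`) stands at < 1 ug/mL and this is a limit of the assay. Compound 3 (`O=C(Nc1ccc([N+](=O)[O-])c(Cl)c1)c1cc(Cl)ccc1O`) stands at < 1 ug/mL and this too is a limit of the assay.

Compound 4 (`COc1cc([N+](=O)[O-])ccc1NC(=O)c1cc(Cl)ccc1O`) has not yet been measured. It departs from compound 2 by a single change, methoxy in place of hydrogen on an aromatic carbon that is, methoxy in place of hydrogen on an aromatic carbon. For the measured compounds named here, the one measured step that bears on it brings in a different group, chloro, and it shows an at least 6.4-fold lower number from compound 2 to compound 3 (0.80 log units; beyond the scatter) as its outcome. On these data alone, that step ends at a limit, so its full size stays open, and the set as a whole shows the limit of < 1 ug/mL in this assay, at which 2 of the 3 values shown sit, as its floor. Going by the values given here, with only that loose precedent from compound 3, a lower number is expected rather than no change. The estimated change is a 2.6-fold lower number from compound 2 to compound 4 (0.41 log units; beyond the scatter) and it is expected to be modest. Compound 4 is therefore estimated at 2.5 ug/mL with an expected range from 1 ug/mL to 7 ug/mL in this assay when it is measured.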

Compound 4, solubility: 9.2 ug/mL
Beside the measured number, compound 4's estimate is 3.7-fold (0.57 log units) below it; measured number above the stated range.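

In this assay, the methoxy step reads a 1.4-fold higher number from compound 2 to compound 4 (0.16 log units; within the scatter), so on this aromatic carbon, ortho to a large group and meta to a nitro group, methoxy brings no change beyond the scatter. Among the compounds shown here, the one earlier step, with chloro, reads an at least 6.4-fold lower number from compound 2 to compound 3 (0.80 log units; beyond the scatter) and ends at a limit, and that outcome does not recur with methoxy at this place. Compound 4 gives a number rather than a limit, so it stays off the floor at which compound 1 and compound 3 sit: the limit of < 1 ug/mL in this assay, at which 2 of the 4 values shown sit.

On these data alone, what a longer chain such as butoxy, an amine or a carboxylic acid would do on this same carbon remains open. The compounds shown also do not tell whether chloro at this carbon, with the rest of compound 2 unchanged, would behave as methoxy does here or as chloro does in compound 3, so the part played by the group and the part played by its place remain unseparated.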